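A few compounds are considered here, and "the series" means these few. Any claim that something is new, unique, unknown or untested is made for them only; others in the source may bear on it.

Measured so far:
compound 1 `Nc1nc(O)c2c(n1)n(C1OC(CO)[C@@H](O)[C@H]1O)c(=O)n2C/C=C/c1ccccc1` — 103 uM
compound 2 `C=CCn1c(=S)n(C2OC(COCc3ccccc3)[C@H]3OC(C)(C)O[C@@H]23)c2nc(N)nc(O)c21` — 47 uM
compound 3 `C=CCn1c(=O)n(C2OC(CO[Si](C)(C)C(C)(C)C)[C@@H](O)[C@H]2O)c2nc(N)nc(O)c21` — 1 uM

In a functional assay (B cells) with Mus musculus as the target (a higher number here means that more compound is needed for the effect, a lower number that less compound is needed), compound 1 gives 103 uM, the highest of the three numbers; compound 2 sits nearest, and compound 3 furthest away with 1 uM.

Compound 4 `Cn1c(=O)n(C2OC(CO)[C@@H](O)[C@H]2O)c2nc(N)nc(O)c21` is not yet measured. It differs from compound 1 in one place: hydrogen in place of 2-phenylethenyl on a saturated chain carbon bound to an aromatic nitrogen. Among the measured compounds shown here, no pair of measured compounds differs in exactly this way, so nothing here tells how this change moves the read-out in this assay.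

For compound 4 the expectation is a modest rise in the number, a step of a 1.5-fold higher number from compound 1 to compound 4 (0.16 log units; within the scatter), though a change in the other direction cannot be excluded. Compound 4 is estimated at 150 uM, with a likely range from 30 uM to 600 uM.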

Compound 4, concentration for half-maximal effect: 10 uM
Estimate against measurement, compound 4: 15-fold (1.18 log units) above; measured number outside the range, below it.
By their numbers in this assay, from the lowest: compound 3; then compound 4; then compound 2; then compound 1.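

In this assay, 3-phenylprop-2-en-1-yl gives way to methyl at this position, and hydrogen in place of 2-phenylethenyl gives a 10-fold lower number from compound 1 to compound 4 (1.01 log units; beyond the scatter), a large step beyond the scatter. Among the compounds shown here, this is the first one-place reading at this position, and it shows that the phenyl ring and the double bond of this group are not required for the effect, with the smaller methyl compound needing less compound. Nothing measured bears on the reason for this step.

As far as these compounds go, whether the step follows the phenyl ring, the double bond or the chain length stays open, and a propyl or benzyl group at this position would help separate these. Also open, from the compounds shown here alone, is whether the same change would carry over to the silyl-protected sugar of compound 3.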